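Substituent on the aromatic nitrogen: hydrogen, carbamoyl, methyl

The source may hold more compounds than are shown below. What is called first, only, known or untested is meant among the compounds shown, and "the series" means these compounds.

Measured so far:
compound 1 `O=C(c1ccn2c1CSC2c1cccnc1)c1c[nH]c2cc(-c3ccc(F)cc3)ccc12`: 75 nM
compound 2 `NC(=O)n1cc(C(=O)c2ccn3c2CSC3c2cccnc2)c2ccc(-c3ccc(F)cc3)cc21`: 6 nM

Going by the values given here, in a functional assay (Oryctolagus cuniculus) for antagonist activity at platelet-activating factor receptor (Cavia porcellus) (on this read-out lower numbers stand for stronger inhibition and higher numbers for weaker inhibition), compound 2 holds the lowest of the two numbers; the single measured step is a 13-fold lower number from compound 1 to compound 2 (1.10 log units; beyond the scatter). Compound 3 `Cn1cc(C(=O)c2ccn3c2CSC3c2cccnc2)c2ccc(-c3ccc(F)cc3)cc21` differs from compound 2 by methyl in place of carbamoyl on an aromatic nitrogen. Among the compounds with values here, only that one step bears on this change, and it was large. Within the data shown here, a methyl here has no measured precedent, so part of the gain tied to the carbamoyl is expected to be lost, the expected step being a 5.0-fold higher number from compound 2 to compound 3 (0.70 log units; beyond the scatter). Compound 3 is therefore estimated at 30 nM, with a range of 8 nM to 120 nM.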

Compound 3, inhibition constant: 7 nM
Estimate against measurement, compound 3: 4.3-fold (0.63 log units) above, and the stated range ends above it.
By their numbers in this assay, from the lowest: compounds 2 and 3 (each within the scatter of the next); then compound 1.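

In this assay methyl in place of carbamoyl on the aromatic nitrogen gives a 1.2-fold higher number from compound 2 to compound 3 (0.07 log units; within the scatter) and leaves the two compounds indistinguishable. Methyl in place of hydrogen gives an 11-fold lower number from compound 1 to compound 3 (1.03 log units; beyond the scatter) and shows that the large gain at this nitrogen does not depend on carbamoyl, since it also appears with a single carbon and no hydrogen-bond donor or acceptor. Nothing available gives a reason for this result.

From the compounds shown here alone, whether ethyl or a longer chain on this nitrogen holds the same level remains open. So does the effect of a chain ending in an amine or a carboxylic acid.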